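The source may report more compounds than this note shows. Statements on the series, on what has been measured and on what is new or still open speak of the compounds shown alone.

Compound 1 `COc1ccccc1-c1nc2cc(F)ccc2o1`: 360 nM
Compound 2 `COc1ccc(-c2nc3ccccc3s2)cc1OC`: 52700 nM
Compound 3 `COc1cc(OC)cc(-c2nc3cc(F)ccc3s2)c1`: 1230 nM

These numbers come from a functional assay on MCF7 cells (Homo sapiens) for inhibition; on this read-out higher numbers stand for weaker inhibition and lower numbers for stronger inhibition. Compound 2, at 52700 nM, has the highest number of the three and so the weakest inhibition, well beyond the scatter of repeat measurements against both of the others.

Compound 4 `COc1ccc(-c2nc3cc(Cl)ccc3s2)cc1OC` is built from compound 2 by one change: chloro in place of hydrogen on an aromatic carbon, a chloro in place of a hydrogen on an aromatic carbon of the six-membered ring of carbon only, part of the fused system.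

Among the compounds with values here, no measured pair isolates a change like this one, so any expectation rests on indirect evidence. Compound 3 also carries a halogen on the shared core and gives 1230 nM, although it differs from compound 2 in other ways too. A sizeable fall in the number therefore seems likely, but with wide uncertainty. The expected change is an 11-fold lower number from compound 2 to compound 4 (1.02 log units; beyond the scatter), toward stronger inhibition. For compound 4 the estimated value is 5000 nM, with an expected range from 500 nM to 40000 nM.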

Compound 4, half-maximal inhibitory concentration: 27900 nM
Estimate against measurement, compound 4: 5.6-fold (0.75 log units) below, and the stated range covers the measured number.
By their numbers in this assay, from the lowest: compound 1; then compound 3; then compounds 4 and 2 (each within the scatter of the next).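

In this assay, adding a chloro on an aromatic carbon of the six-membered ring of carbon only, part of the fused system, gives a 1.9-fold lower number from compound 2 to compound 4 (0.28 log units; within the scatter). Within the data shown here, this is the first comparison here that isolates a single change, and it shows that on this core, swapping hydrogen for chloro at this position leaves the two compounds indistinguishable given the usual spread of repeat measurements. No supporting measurement is available to explain this result.

On these data alone, it remains open whether a different group at this position, such as an amine or a carboxylic acid, would shift the number beyond that spread. As far as these compounds go, it is also open whether chloro would give a similarly small step on a compound with a different arrangement of methoxy groups on the other aromatic ring.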